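The source may report more compounds than this note shows. Statements on the series, on what has been measured and on what is new or still open speak of the compounds shown alone.

Compound 1 `CCC(=O)N(Cc1ccc(OC)c(O)c1)c1cc(OC)c(OC)c(OC)c1` gives the lowest of the three numbers in a functional assay on KYSE-450 cells (Homo sapiens) for inhibition, read by MTT assay, with a stated time of 48 h (on this read-out higher numbers stand for weaker inhibition and lower numbers for stronger inhibition), with a value of 98 nM. Going by the values given here, compound 2 `COc1ccc(CNc2cc(OC)c(OC)c(OC)c2)cc1C` gives 73800 nM in this assay, and compound 3 `COc1ccc(CNc2cc(OC)c(OC)c(OC)c2)cc1Br` gives 39800 nM; the only measured step, a 1.9-fold lower number from compound 2 to compound 3 (0.27 log units; within the scatter), lies within the scatter. Compound 4 `C#CC(=O)N(Cc1ccc(OC)c(O)c1)c1cc(OC)c(OC)c(OC)c1` differs from compound 1 in one place: ethynyl in place of ethyl on a carbonyl carbon. Among the compounds with values here, no measured step bears on this change, since the one step recorded concerns a bromo in place of methyl on an aromatic carbon, not a change at the carbonyl carbon. Without a comparable step, compound 4 is expected to stay close to compound 1, with the estimated step of a 1.0-fold higher number from compound 1 to compound 4 (0.01 log units; within the scatter) within the scatter. Compound 4 is therefore estimated at 100 nM, in a range from 30 nM to 350 nM.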

Compound 4, half-maximal inhibitory concentration: 570 nM
Beside the measured number, compound 4's estimate is 5.7-fold (0.76 log units) below it; the measured number lies above the stated range.
By their numbers in this assay, from the lowest: compound 1; then compound 4; then compounds 3 and 2 (each within the scatter of the next).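

In this assay, ethynyl in place of ethyl on a carbonyl carbon gives a 5.8-fold higher number from compound 1 to compound 4 (0.76 log units; beyond the scatter), so this position responds to an exchange of two-carbon groups, a change beyond the scatter that the earlier step at an aromatic carbon could not reveal. The result covers this single exchange and sets no trend for the position. No available evidence accounts for the size of this step. The compounds shown leave open how a longer chain, a cyclopropyl group or an amine on this carbonyl carbon would compare with compound 1 and compound 4.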